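Swapping dimethylamino for piperidin-1-yl in compound 3

The source may report more compounds than this note shows. Statements on the series, on what has been measured and on what is new or still open speak of the compounds shown alone.

In an ADME assay on MRC5 cells (Homo sapiens) for antiproliferative activity, read by fluorescence and resazurin assay, with a stated time of 68 h (a lower number here means that less compound is needed, a higher number that more compound is needed for the effect), compound 1 `Cc1ccc(-c2cc(C(=O)Nc3cccnc3)c3ccccc3n2)cc1` gives > 50000 nM as a limit of the assay, not a number. Within the data shown here, compound 2 `Cc1ccc(-c2cc(C(=O)NCCN(C)C)c3cc(Cl)ccc3n2)cc1` gives 9000 nM as the only true number so far, which makes it the sole point of reference here. Compound 3 `Cc1ccc(-c2cc(C(=O)NCCN3CCCCC3)c3cc(Cl)ccc3n2)cc1` differs from compound 2 in one place: piperidin-1-yl stands in place of dimethylamino on a saturated chain carbon, two bonds along the chain from an amide-type nitrogen (piperidin-1-yl in place of dimethylamino on a saturated chain carbon, two bonds along the chain from an amide-type nitrogen). Among the measured compounds shown here, no measured step speaks to this swap, so with compound 2 at 9000 nM as the only guide, a large change in this assay is not expected. The expected shift a 1.5-fold lower number from compound 2 to compound 3 (0.18 log units; within the scatter) leans towards less compound being needed, but it is not expected to go beyond the usual scatter. The estimated value for compound 3 is 6000 nM (expected range 2000 nM to 20000 nM).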

Compound 3, half-maximal effective concentration: 7000 nM
Compound 3: the middle estimate sits 1.2-fold (0.07 log units) below what was measured; low and high end bracket the measured number.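

In this assay the swap gives a 1.3-fold lower number from compound 2 to compound 3 (0.11 log units; within the scatter), so the two compounds cannot be told apart. Among these compounds, this is the first pair that differs in one place, and it shows that, on a saturated chain carbon, two bonds along the chain from an amide-type nitrogen, the piperidin-1-yl ring can stand in place of the open dimethylamino group with no readable shift. Compound 1 differs from both in more than one place and gives only a limit, not a number: the limit of > 50000 nM in this assay, at which 1 of the 3 values shown sits.

As far as these compounds go, whether an amine is needed at this place at all stays open, since a morpholin-4-yl ring, a carboxylic acid or a longer chain could read differently. A single pair on one shared core also cannot tell whether the same swap would hold on another core.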